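From 3-Methylphenyl to 2-Chlorophenyl on the Triazole Nitrogen

A few compounds are considered here, and "the series" means these few. Any claim that something is new, unique, unknown or untested is made for them only; others in the source may bear on it.

Measured in a functional assay on A549 cells (Homo sapiens) for antiproliferative activity, read by MTT assay, with a stated time of 48 h; a higher number here means a weaker inhibitor, a lower number a stronger inhibitor:
compound 1 `N#CC1=C(N)Oc2c(c3nc4ccccc4nc3c3ccccc23)C12C(=O)N(Cc1cnnn1-c1ccc(F)cc1)c1ccccc12` gives > 50000 nM, a limit of the assay rather than a number.
compound 2 `Cc1cccc(-n2nncc2CN2C(=O)C3(C(C#N)=C(N)Oc4c(N)cc5nc6ccccc6nc5c43)c3ccccc32)c1` gives 12300 nM.

Compound 2 holds the only number shown. The value of compound 1 is a limit (the limit of > 50000 nM in this assay, at which 1 of the 2 values shown sits). Compound 3 `N#CC1=C(N)Oc2c(N)cc3nc4ccccc4nc3c2C12C(=O)N(Cc1cnnn1-c1ccccc1Cl)c1ccccc12` differs from compound 2 in one place: 2-chlorophenyl in place of 3-methylphenyl on an aromatic nitrogen. Going by the values given here, no pair of measured compounds isolates this change, so no measured step guides the expectation. The change is expected to leave the inhibitory concentration near where compound 2 sits, with the step of a 1.0-fold lower number from compound 2 to compound 3 (0.01 log units; within the scatter) not beyond the usual scatter. Compound 3 is estimated at 12000 nM, in the range 4000 nM to 40000 nM.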

Compound 3, half-maximal inhibitory concentration: 29800 nM
Compound 3: the middle estimate sits 2.5-fold (0.40 log units) below what was measured; the range from low to high includes it.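

In this assay, the group on the triazole nitrogen proves able to shift the reading: 2-chlorophenyl in place of 3-methylphenyl gives a 2.4-fold higher number from compound 2 to compound 3 (0.38 log units; beyond the scatter), even though both groups count the same heavy atoms and neither has hydrogen-bond donors or acceptors. Going by these compounds alone, this is the first measured step at this position, and it is a modest one towards weaker inhibition. Nothing measured here gives a cause for it. From the compounds shown here alone, whether the step comes from the chlorine or from where it sits stays open, as group and place change together. Also open, going by these compounds, is how a plain phenyl, or a phenyl carrying an amine or a carboxylic acid, would read.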